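Swapping methyl for chloro on a cytotoxicity read-out

The compounds below may be only part of what the source reports. "The series", "measured", "known", "first", "only" and "open" are said of these compounds alone.

Measured compounds:
- compound 1, `O=C1CSC(c2cccc(Cl)c2)N1CCN1CCCCC1`: 20%
- compound 2, `O=C1CSC(c2cccc(O)c2)N1CCN1CCCCC1`: 13%
- compound 3, `Cc1ccc(C2SCC(=O)N2CCN2CCCCC2)cc1`: 13%

All three share one core and differ only in the aromatic ring attached to it. In an ADME assay on Vero cells (Chlorocebus sabaeus) for cytotoxicity, read by neutral red uptake, tested at 1575 ug/mL (on this read-out higher numbers stand for a weaker effect at the one concentration tested and lower numbers for a stronger effect), compound 1 gives 20%, compound 2 gives 13% and compound 3 gives 13%. On these numbers compound 3 sits at the same read-out as compound 2, and the steps of no change at the digits printed from compound 2 to compound 3 (within the scatter) and a number 7 percentage points lower from compound 1 to compound 3 (within the scatter) both stay inside the usual scatter, as does a number 7 percentage points lower from compound 1 to compound 2 (within the scatter).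

Compound 4, `O=C1CSC(c2ccc(Cl)cc2)N1CCN1CCCCC1`, is not yet measured. It differs from compound 3 by chloro in place of methyl on an aromatic carbon. Among the compounds with values here, no measured step swaps exactly these two groups, but the nearest comparisons are a number 7 percentage points lower from compound 1 to compound 3 (within the scatter), where a chlorine-bearing ring gives way to a methyl-bearing one, and a number 7 percentage points lower from compound 1 to compound 2 (within the scatter), where chloro is replaced on the ring. Both are small, so the step of a number 3 percentage points higher from compound 3 to compound 4 (within the scatter) is expected to fall within the scatter as well, with no clear direction. Compound 4 is therefore estimated at 16%, with a likely range from 6% to 28%.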

Compound 4, a percentage reported as activity, at one concentration (the size of the read-out at that concentration, not a potency): 13%
The estimate for compound 4 lay 3 percentage points above the measured number; the range from low to high includes it.
By their numbers in this assay, from the lowest: compounds 2, 3, 4 and 1 (each within the scatter of the next).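

Within the data shown here, compound 4 gives the first direct swap of these two groups at one place, on an aromatic carbon para to a large group, and in this assay the change of methyl to chloro reads as no change at the digits printed from compound 3 to compound 4 (within the scatter), so this read-out does not separate them here. The 4-chlorophenyl and 3-chlorophenyl compounds can also now be compared, which shows what moving the chlorine around the ring does: a number 7 percentage points lower from compound 1 to compound 4 (within the scatter), while replacing 3-hydroxyphenyl with 4-chlorophenyl gives no change at the digits printed from compound 2 to compound 4 (within the scatter), so none of the ring changes among these compounds stands clear of the usual scatter. No measurement at hand bears on why the numbers sit so close together.

Still open, on these data alone, is whether a quite different group at this same place, such as an amine, a carboxylic acid or a longer chain like butyl, would move the read-out beyond the scatter. These numbers also come from one concentration only, so they leave open whether these compounds would separate at lower concentrations, where the read-out might be less compressed.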